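The source may hold more compounds than are shown below. What is called first, only, known or untested is meant among the compounds shown, and "the series" means these compounds.

Of the compounds shown here, three that share one core have been tested in an ADME assay on the whole organism for pharmacokinetics, with Homo sapiens as the target; a higher number here means that a larger share of the oral dose reaches the circulation, a lower number that a smaller share of the oral dose reaches the circulation. Compound 1 `O=[N+]([O-])c1ccc(NS(=O)(=O)c2ccc3nc(-c4ccccc4)c(-c4ccccc4)nc3c2)cc1` gives 87.6%. Compound 2 `CC(=O)c1cccc(NS(=O)(=O)c2ccc3nc(-c4ccccc4)c(-c4ccccc4)nc3c2)c1` gives 96.9%, and compound 3 `O=C(O)c1ccccc1NS(=O)(=O)c1ccc2nc(-c3ccccc3)c(-c3ccccc3)nc2c1` gives 83.6%. Among these three, compound 1 stands second highest; its gaps to the others, a number 9.3 percentage points higher from compound 1 to compound 2 (within the scatter) and a number 4 percentage points lower from compound 1 to compound 3 (within the scatter), are both within the scatter, while a number 13.3 percentage points lower from compound 2 to compound 3 (beyond the scatter) is the only step among them that reaches beyond it.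

Compound 4 `Cc1ccnc(NS(=O)(=O)c2ccc3nc(-c4ccccc4)c(-c4ccccc4)nc3c2)c1` has not yet been measured. It differs from compound 1 at one place: 4-methylpyridin-2-yl in place of 4-nitrophenyl on a sulfonamide nitrogen. The group on the sulfonamide nitrogen is exchanged, which is also the place changed in the measured steps, though 4-methylpyridin-2-yl is new here. Both measured steps away from compound 1 stayed within the scatter, so the expectation for this assay is no step beyond the scatter, with a number 0.4 percentage points higher from compound 1 to compound 4 (within the scatter) as the expected change. Compound 4 is therefore estimated at 88%, with a range from 72% to 99%.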

Compound 4, oral bioavailability: 100%
Compound 4: the middle estimate sits 12 percentage points below what was measured, and the stated range ends below it.
By their numbers in this assay, from the lowest: compounds 3, 1, 2 and 4 (each within the scatter of the next, the first and the last beyond it).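

In this assay, among the compounds shown here, the group on the sulfonamide nitrogen can now be seen to matter beyond the scatter when starting from compound 1 (a number 12.4 percentage points higher from compound 1 to compound 4 (beyond the scatter)), which neither earlier step from that compound showed. 4-Methylpyridin-2-yl, the first group here with a hetero atom in its six-membered aromatic ring, also stands clear of 2-carboxyphenyl (a number 16.4 percentage points higher from compound 3 to compound 4 (beyond the scatter)), but not of 3-acetylphenyl, a ring of carbon only (a number 3.1 percentage points higher from compound 2 to compound 4 (within the scatter)), so a ring of carbon only can do equally well at this position. No measurement at hand explains these steps.

As far as these compounds go, it remains open whether the ring nitrogen or the methyl group accounts for the step from compound 1. Plain pyridin-2-yl and 4-methylphenyl on the same nitrogen would separate the two, and an amine on the ring would test a further kind of group.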